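The source may hold more compounds than are shown below. What is called first, only, known or untested is meant among the compounds shown, and "the series" means these compounds.

Working notes on the series: in a functional assay on THP-1 cells (Homo sapiens) for inhibition, read by sulforhodamine B assay, with a stated time of 48 h, tested at 50 uM (a lower number here means less inhibition of growth, a higher number more inhibition of growth at the concentration tested), compound 1 `COc1cc(/C=C/C(=O)/C=C/c2cccc3ccccc23)ccc1OCc1cn(CCCCCOc2cc(=O)oc3ccccc23)nn1` gives 44% and compound 2 `COc1cccc(/C=C/C(=O)/C=C/c2ccc(OCc3cn(CCCCCOc4cc(=O)oc5ccccc45)nn3)c(OC)c2)c1` gives 37%, so compound 2 stands within the scatter of the only other measured number. Compound 3 `COc1ccc(/C=C/C(=O)/C=C/c2ccc(OCc3cn(CCCCCOc4cc(=O)oc5ccccc45)nn3)c(OC)c2)cc1` differs from compound 2 by 4-methoxyphenyl in place of 3-methoxyphenyl on a double-bonded chain carbon bound to a double-bonded chain carbon, with 4-methoxyphenyl in place of 3-methoxyphenyl on a double-bonded chain carbon bound to a double-bonded chain carbon. Among the compounds with values here, the one measured step at this place is a number 7 percentage points lower from compound 1 to compound 2 (within the scatter). No step beyond the scatter is therefore expected in this assay, in either direction. The estimated change is a number 3 percentage points higher from compound 2 to compound 3 (within the scatter). For compound 3 the expected value is 40%, with an estimated range of 27% to 53%.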

Compound 3, percent growth inhibition at one concentration: 39%
Compound 3: middle estimate off by 1 percentage points, on the high side, within the range that was stated.
By their numbers in this assay, from the lowest: compounds 2, 3 and 1 (each within the scatter of the next).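

In this assay, the change to 4-methoxyphenyl in place of 3-methoxyphenyl on a double-bonded chain carbon bound to a double-bonded chain carbon gives a number 2 percentage points higher from compound 2 to compound 3 (within the scatter), so this change of the methoxy group's attachment shows no readable effect. The change to 4-methoxyphenyl in place of naphthalen-1-yl gives a number 5 percentage points lower from compound 1 to compound 3 (within the scatter), so all three groups at this place lie within the scatter of one another. No supporting data bear on these results.

On these data alone, whether an amine or a carboxylic acid in place of the methoxy group would give a step beyond the scatter stays open.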